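This account rests on a few compounds, and the source may have more. Where it says the series, first, only, none or still open, it means among the compounds named here.

Measured in an ADME assay on NCM460 cells (Homo sapiens) for cytotoxicity, read by CCK-8 assay, with a stated time of 48 h; a higher number here means a weaker inhibitor, a lower number a stronger inhibitor:
- Compound 1 `COc1ccc(/C=C\c2cc(OC)c(OC)c(OC)c2)cc1OCc1ccc(CN2C[C@H](O)C[C@@H]2C(=O)O)cc1`: > 50000 nM, a limit
- Compound 2 `COc1ccc(/C=C\c2cc(OC)c(OC)c(OC)c2)cc1OCc1ccc(CN2CC(C(=O)O)C2)cc1`: > 50000 nM, a limit

Compound 2 has no exact number, only its limit of > 50000 nM. The same holds for compound 1, as the limit of > 50000 nM in this assay, at which 2 of the 2 values shown sit, shows.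

The unmeasured compound 3 `COc1ccc(/C=C\c2cc(OC)c(OC)c(OC)c2)cc1OCc1ccc(CN2CC[C@H](O)C2)cc1` differs from compound 2 by 3-hydroxypyrrolidin-1-yl in place of 3-carboxyazetidin-1-yl on a saturated chain carbon bound to an aromatic carbon. In words, 3-hydroxypyrrolidin-1-yl replaces 3-carboxyazetidin-1-yl on a saturated chain carbon bound to an aromatic carbon.

Among the measured compounds shown here, the only measured step, a step that the two limits leave unreadable from compound 1 to compound 2, changes the group at this same place, but it gives no size to carry forward. Both measured compounds also keep a carboxy group, which compound 3 lacks, so neither shows what its loss does.

With little to go on, the expected change is a modest, uncertain move toward stronger inhibition in this assay, estimated as an at least 2.0-fold lower number from compound 2 to compound 3 (0.30 log units; that floor lies within the scatter). The expected value for compound 3 is 25000 nM, within an estimated range of 5000 nM to 60000 nM.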

Compound 3, half-maximal inhibitory concentration: 51000 nM
The estimate for compound 3 lay 2.0-fold (0.31 log units) below the measured number; low and high end bracket the measured number.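

No step can be read among compound 1, compound 2 and compound 3 in this assay because compound 1 and compound 2 carry only a limit, not an exact number: the limit of > 50000 nM in this assay, at which 2 of the 3 values shown sit.

In this assay the compounds shown leave open how the three groups on the saturated chain carbon rank against one another.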